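Changing the substituted phenyl group on a shared core

This account rests on a few compounds, and the source may have more. Where it says the series, first, only, none or still open, it means among the compounds named here.

In a functional assay on KB cells (Homo sapiens) for antiproliferative activity, read by sulforhodamine B assay, with a stated time of 3 days (on this read-out lower numbers stand for an effect already at smaller amounts and higher numbers for an effect only at larger amounts of compound), compound 1 `CCC1=C(O)c2c(oc(-c3ccccc3)cc2=O)C(CC)(CC)C1=O`, which carries a plain phenyl group, gives only a limit of > 236 uM. For the measured compounds named here, compound 2 `CCC1=C(O)c2c(oc(-c3ccc(OC)c(F)c3)cc2=O)C(CC)(CC)C1=O` shares that core, carries 3-fluoro-4-methoxyphenyl instead, and gives 26.7 uM, the only exact number so far. Going by the values given here, the single measured step is an at least 8.8-fold lower number from compound 1 to compound 2 (0.94 log units; beyond the scatter). Compound 3 `CCC1=C(O)c2c(oc(-c3cc(C)c(O)c(C)c3)cc2=O)C(CC)(CC)C1=O` now brings 4-hydroxy-3,5-dimethylphenyl in place of 3-fluoro-4-methoxyphenyl on the same aromatic carbon, a change counted as 4-hydroxy-3,5-dimethylphenyl in place of 3-fluoro-4-methoxyphenyl on an aromatic carbon. Both groups are substituted phenyl rings, whereas the measured step started from an unsubstituted one. That step therefore gives no direct size for swapping one substituted ring for another, so no clear shift in this assay is expected, though uncertainty remains wide. The expected change is a 1.1-fold higher number from compound 2 to compound 3 (0.05 log units; within the scatter). For compound 3, the estimated value is 30 uM, with an expected range of 10 uM to 90 uM.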

Compound 3, concentration for half-maximal effect: 18.3 uM
The estimate for compound 3 lay 1.6-fold (0.21 log units) above the measured number, within the range that was stated.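

In this assay, the position next to the ring oxygen now holds a second substituted phenyl ring, which gives an at least 12-fold lower number from compound 1 to compound 3 (1.11 log units; beyond the scatter), so the drop from the plain phenyl group is not confined to 3-fluoro-4-methoxyphenyl. Exchanging one substituted ring for the other gives a 1.5-fold lower number from compound 2 to compound 3 (0.16 log units; within the scatter), so these two groups cannot be told apart here, even though only 4-hydroxy-3,5-dimethylphenyl carries a hydrogen-bond donor. The size of the step from the plain phenyl group is only a minimum, because compound 1 gives a limit and not a number: the limit of > 236 uM in this assay, at which 1 of the 3 values shown sits.

Which substituents account for the lower numbers stays open, for instance whether a lone hydroxy or a lone methoxy group would do the same. Also open, as far as these compounds go, is how an amine or a carboxylic acid on this phenyl ring would read in this assay.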